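Pyrrolidin-1-yl in place of butyl on the amine side chain

A few compounds are considered here, and "the series" means these few. Any claim that something is new, unique, unknown or untested is made for them only; others in the source may bear on it.

For the measured compounds named here, compound 3 `CCCCCCN/C(=N\C1=NC(=O)C(=O)N1C(C)C)Nc1ccc(Cl)c(Cl)c1` is the only member of the series with a number in an in vitro ADME assay on microsomes from liver (Mus musculus) for metabolic stability, read by LC-MS (a higher number here means that the compound lasts longer, a lower number that the compound disappears faster), giving 0.579 h. Compound 1 `C=CCON/C(=N\C1=NC(=O)C(=O)N1C(C)C)Nc1ccc(Cl)c(Cl)c1` reaches only a limit in this assay, > 1 h. Compound 2 `CC(C)N/C(=N\C1=NC(=O)C(=O)N1C(C)C)Nc1ccc(Cl)c(Cl)c1` likewise gives only a limit, > 1 h. The steps of an at least 1.7-fold lower number from compound 1 to compound 3 (0.23 log units; that floor lies within the scatter) and an at least 1.7-fold lower number from compound 2 to compound 3 (0.23 log units; that floor lies within the scatter) both alter the substituent on the amine nitrogen, while compound 1 against compound 2 shows a step that the two limits leave unreadable from compound 1 to compound 2. Compound 4 `CC(C)N1C(=O)C(=O)N=C1/N=C(\NCCN1CCCC1)Nc1ccc(Cl)c(Cl)c1` differs from compound 3 by pyrrolidin-1-yl in place of butyl on a saturated chain carbon, two bonds along the chain from an amine nitrogen: hexylamino becomes (2-(pyrrolidin-1-yl)ethyl)amino. Both measured steps toward hexyl lowered the number, so for compound 4 a step back upward is expected, a 1.6-fold higher number from compound 3 to compound 4 (0.19 log units; within the scatter), bounded by the limit of > 1 h in this assay, at which 2 of the 3 values shown sit. The expected value for compound 4 is 0.9 h, with a range from 0.45 h to 1.8 h.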

Compound 4, half-life: > 1 h
Compound 4 was reported as a limit; the forecaster's own chance of this, stated with the estimate: 40%; middle value at least 1.1-fold (0.04 log units) away from the limit.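

Pyrrolidin-1-yl in place of butyl on this chain gives an at least 1.7-fold higher number from compound 3 to compound 4 (0.23 log units; that floor lies within the scatter), so in this assay the chain carbon two bonds along from the amine nitrogen tolerates a change that carries a ring and a nitrogen. Compound 4 gives a limit, not a number, and its steps from compound 1 and compound 2 cannot be read. Compound 3 remains the only compound with a number: the limit of > 1 h in this assay, at which 3 of the 4 values shown sit.

Still open, from the compounds shown here alone, is how far compound 4 actually lies from compound 1 and compound 2. A cyclopentyl or diethylamino group on the same ethyl chain would help separate the contribution of the ring from that of the nitrogen.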